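The compounds below may be only part of what the source reports. "The series", "measured", "known", "first", "only" and "open" are said of these compounds alone.

In a functional assay on HEK293 cells for agonist activity at G-protein coupled receptor 39 (Homo sapiens), read by scintillation proximity assay and inositol phosphate accumulation, with a stated time of 75 min (a higher number here means that more compound is needed for the effect, a lower number that less compound is needed), compound 3 `Cc1nn(-c2ncnc3nc[nH]c23)c2c1C(OCc1ccc(F)cc1)CC(=O)N2` gives 126 nM, the lowest of the three numbers measured. Its nearest neighbour is compound 1 `Cc1nn(-c2ncnc3nc[nH]c23)c2c1C(OCc1ccc(Cl)cc1Cl)CC(=O)N2`, which in this assay gives 243 nM; the step of a 1.9-fold lower number from compound 1 to compound 3 (0.29 log units; within the scatter) stays within the scatter of repeated measurements. Further away is compound 2 `CCCCCCCCOC1CC(=O)Nc2c1c(C)nn2-c1ncnc2nc[nH]c12`, which in this assay gives 388 nM; the step of a 3.1-fold lower number from compound 2 to compound 3 (0.49 log units; beyond the scatter) is beyond the scatter.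

Compound 4 `Cc1nn(-c2ncnc3nc[nH]c23)c2c1C(OCCc1ccccc1)CC(=O)N2` differs from compound 3 by one change: benzyl in place of 4-fluorophenyl on a saturated chain carbon bound to an oxygen on a saturated carbon. For the measured compounds named here, two measured steps bear on this: the step of a 1.9-fold lower number from compound 1 to compound 3 (0.29 log units; within the scatter), where one aromatic ring replaced another, and the step of a 3.1-fold lower number from compound 2 to compound 3 (0.49 log units; beyond the scatter), where an aromatic ring replaced a heptyl chain. Compound 4 keeps a six-membered aromatic ring at this place, so a step like the first, not the second, is expected, and in this assay the step of a 1.4-fold higher number from compound 3 to compound 4 (0.15 log units; within the scatter) is expected to stay within the scatter. On that basis compound 4 is estimated to give 180 nM in this assay, with a range from 70 nM to 450 nM.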

Compound 4, half-maximal effective concentration: 40 nM
For compound 4 the middle estimate is 4.5-fold (0.65 log units) above the measured one; measured number outside the range, below it.
By their numbers in this assay, from the lowest: compound 4; then compounds 3, 1 and 2 (each within the scatter of the next, the first and the last beyond it).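

In this assay, for the compounds shown here, the group on this oxygen proves more sensitive than the earlier compounds showed: phenethyloxy in place of (4-fluorobenzyl)oxy keeps one six-membered aromatic ring of carbon only, yet gives a 3.2-fold lower number from compound 3 to compound 4 (0.50 log units; beyond the scatter). The gaps to the other two are larger, with a 6.1-fold lower number from compound 1 to compound 4 (0.78 log units; beyond the scatter) and a 9.7-fold lower number from compound 2 to compound 4 (0.99 log units; beyond the scatter), so compound 4 is the most potent of the four shown. No measurement at hand explains why this change lowers the number.

The step removes the fluorine and adds a carbon together, and the compounds shown do not separate these two changes. Going by these compounds, how a longer chain ending in a phenyl ring, or a phenethyl group carrying an amine on its ring, would behave also remains open.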